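Phenyl substitution on the shared core: permeability notes

A few compounds are considered here, and "the series" means these few. Any claim that something is new, unique, unknown or untested is made for them only; others in the source may bear on it.

Among the measured compounds shown here, compound 1 `Cc1ccccc1-c1nc(CN2CCC(C(=O)NCCCN3CC4CCCC(C4)C3)CC2)c(C)o1` is the only member of the set with a number in a physicochemical assay for permeability, using PAMPA; a higher number here means that the compound crosses the layer faster, a lower number that the compound crosses the layer more slowly; in this assay compound 1 gives 331 10^-6 cm/s. Compound 2 `Cc1oc(-c2c(Cl)cccc2Br)nc1CN1CCC(C(=O)NCCCN2C[C@H](C)C[C@H](C)C2)CC1` differs from compound 1 at both outer groups of the shared core, and in this assay compound 2 gives "not determined" (no result reported), so compound 2 stands on no number at all. Compound 3 `Cc1cccc(C)c1-c1nc(CN2CCC(C(=O)NCCCN3C[C@H](C)C[C@H](C)C3)CC2)c(C)o1` is the one still to be measured, and it differs from compound 2 in one place: 2,6-dimethylphenyl in place of 2-bromo-6-chlorophenyl on an aromatic carbon. For the measured compounds named here, no step between two measured compounds is available to set the size of this change. With the two groups counted as alike in size and neither carrying donors or acceptors, a shift no larger than the scatter, in either direction, is expected. Going by the values given here, the only anchor is the value of compound 1. For compound 3 the expected result in this assay is 300 10^-6 cm/s, estimated to fall between 150 10^-6 cm/s and 600 10^-6 cm/s.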

Compound 3, apparent permeability: 254 10^-6 cm/s
Estimate against measurement, compound 3: 1.2-fold (0.07 log units) above; the measured number falls inside the stated range.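

No new step can be read from this result: compound 2 has no number in this assay and compound 1 differs from compound 3 in more than one place. The compounds shown leave open how 2,6-dimethylphenyl compares with 2-bromo-6-chlorophenyl on the shared core. No measurement shown bears on a cause.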